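Aniline substituent swap from compound 2 to compound 3

The compounds below may be only part of what the source reports. "The series", "measured", "known", "first", "only" and "open" are said of these compounds alone.

compound 1 `FC(F)(F)c1ccc(CSc2nc(Nc3ccccc3Cl)c3ccccc3n2)cc1` — > 50000 nM (a limit)
compound 2 `FC(F)(F)c1ccc(CSc2nc(Nc3ccc(C(F)(F)F)cc3)c3ccccc3n2)cc1` — 6170 nM

Among the compounds with values here, in a functional assay on MGC-803 cells (Homo sapiens) for cytotoxicity, read by MTT assay, with a stated time of 72 h (on this read-out higher numbers stand for weaker inhibition and lower numbers for stronger inhibition), compound 2 gives 6170 nM, the only number in the set. For compound 1 the result is a limit, > 50000 nM, consistent with the limit of > 50000 nM in this assay, at which 1 of the 2 values shown sits. Within the data shown here, the sole measured step, an at least 8.1-fold lower number from compound 1 to compound 2 (0.90 log units; beyond the scatter), shows that the ring on the nitrogen matters. Compound 3 `COc1ccc(Nc2nc(SCc3ccc(C(F)(F)F)cc3)nc3ccccc23)cc1` differs from compound 2 by methoxy in place of trifluoromethyl on an aromatic carbon. Among the measured compounds shown here, no measured step exchanges the group at that position, so the precedent is only indirect. For compound 3 the expected value is 12000 nM, with a range from 3000 nM to 45000 nM. The expected step is a 1.9-fold higher number from compound 2 to compound 3 (0.29 log units; within the scatter), a modest weakening that may fall within the scatter.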

Compound 3, half-maximal inhibitory concentration: 13800 nM
Estimate against measurement, compound 3: 1.2-fold (0.06 log units) below; measured number inside the range.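

Exchanging trifluoromethyl for methoxy on this aromatic carbon gives a measurable but modest change, with a 2.2-fold higher number from compound 2 to compound 3 (0.35 log units; beyond the scatter). The methoxy compound still keeps a clear margin over the 2-chlorophenyl compound, with an at least 3.6-fold lower number from compound 1 to compound 3 (0.55 log units; beyond the scatter); the starting value of that step is a limit of the assay, not a number. Nothing measured here accounts for the direction or size of either step.

Still open, on these data alone, is how an amine or a carboxylic acid would read at this same carbon. The compounds shown also do not separate the identity of the chlorine substituent from its place on the ring.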